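The source may report more compounds than this note shows. Statements on the series, on what has been measured and on what is new or still open speak of the compounds shown alone.

Series on the shared core of compound 1 `C=CCCn1cnc2c1c(=O)n(C)c(=O)n2CCC`, varied at the chain on the aromatic nitrogen. In an assay on Cerebral cortex for binding affinity to adenosine receptor A1 (Cavia porcellus), read by radioligand binding (on this read-out lower numbers stand for stronger inhibition and higher numbers for weaker inhibition), compound 1 gives 6000 nM. Compound 2 `CCCn1c(=O)n(C)c(=O)c2c1ncn2CC(N)=O` gives no number but a limit, > 200000 nM, in this assay. Compound 3 `CCCn1c(=O)n(C)c(=O)c2c1ncn2CCC#N` gives 88600 nM in this assay, the highest of the two numbers in hand; its distance to the nearest number is told by a 15-fold higher number from compound 1 to compound 3 (1.17 log units; beyond the scatter), and the remaining step reads an at least 2.2-fold lower number from compound 2 to compound 3 (0.35 log units; beyond the scatter). Compound 4 `CCCn1c(=O)n(C)c(=O)c2c1ncn2CCCN(C)C` is the next compound: (dimethylamino)methyl in place of cyano on a saturated chain carbon, two bonds along the chain from an aromatic nitrogen. The step of a 15-fold higher number from compound 1 to compound 3 (1.17 log units; beyond the scatter) bears most directly: read backwards, vinyl in place of cyano, it brings the number down by as much. The step of an at least 2.2-fold lower number from compound 2 to compound 3 (0.35 log units; beyond the scatter) adds that carbamoyl stands higher still, so the cyano end is not the worst shown. For (dimethylamino)methyl in place of cyano a fall beyond the scatter is expected in this assay, though short of compound 1. Compound 4 is therefore expected at 30000 nM, within 6000 nM to 150000 nM, which is an expected step of a 3.0-fold lower number from compound 3 to compound 4 (0.47 log units; beyond the scatter).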

Compound 4, inhibition constant: > 200000 nM
Compound 4: only a limit was reported (the forecaster's own chance of this, stated with the estimate: 15%); middle value at least 6.6-fold (0.82 log units) away from the limit.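

In this assay the (dimethylamino)methyl end does not bring the number down from the cyano end: the step reads an at least 2.2-fold higher number from compound 3 to compound 4 (0.35 log units; beyond the scatter) and stands as a bound, since the reading for compound 4 is a limit and not a number. The gap to the butenyl chain also widens to at least the size seen for the carbamoyl end, with an at least 33-fold higher number from compound 1 to compound 4 (1.52 log units; beyond the scatter) as the step. So all three nitrogen-bearing chain ends shown at this position sit well above compound 1, and two of them share the assay ceiling: the limit of > 200000 nM in this assay, at which 2 of the 4 values shown sit.

The step between the two limits cannot be read, so the carbamoyl and dimethylamino ends stay unordered. Going by these compounds, whether a hydroxyl end, a carboxylic acid or a longer plain alkyl chain lowers the number toward compound 1 remains open.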